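One more hydroxy on the chain of compound 2

The source may report more compounds than this note shows. Statements on the series, on what has been measured and on what is new or still open speak of the compounds shown alone.

Compound 1 `CCCC(CCC)Nc1cc(Oc2c(OC)cc3cc(C#N)ccc3c2OC)nc(Nc2ccc(C#N)cc2)n1`: > 125000 nM (a limit)
Compound 2 `COc1cc2cc(C#N)ccc2c(OC)c1Oc1cc(NCCCO)nc(Nc2ccc(C#N)cc2)n1`: 23500 nM

Among the measured compounds shown here, in an ADME assay on MT4 cells (Homo sapiens) for cytotoxicity, read by MTT assay, with a stated time of 5 days (on this read-out lower numbers stand for higher toxicity in this test and higher numbers for lower toxicity in this test), compound 2 gives 23500 nM, the only actual number so far. Compound 1 stands at > 125000 nM in this assay, and this is a limit. Compound 3 `COc1cc2cc(C#N)ccc2c(OC)c1Oc1cc(NCC(O)CO)nc(Nc2ccc(C#N)cc2)n1` differs from compound 2 by hydroxy in place of hydrogen on a saturated chain carbon bound to two saturated chain carbons, which turns 3-hydroxypropyl into 2,3-dihydroxypropyl. For the measured compounds named here, the only measured step bearing on this is an at least 5.3-fold lower number from compound 1 to compound 2 (0.72 log units; beyond the scatter). It exchanged the whole group on that nitrogen, a larger change than this one. The expected step is a 1.1-fold higher number from compound 2 to compound 3 (0.04 log units; within the scatter), none beyond the scatter. Compound 3 is estimated at 26000 nM, with an expected range of 10000 nM to 70000 nM.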

Compound 3, half-maximal cytotoxic concentration: 29500 nM
The estimate for compound 3 lay 1.1-fold (0.05 log units) below the measured number, within the range that was stated.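

In this assay, turning 3-hydroxypropyl into 2,3-dihydroxypropyl gives a 1.3-fold higher number from compound 2 to compound 3 (0.10 log units; within the scatter), so the extra hydroxy on this saturated chain carbon brings no change that can be told from the scatter. Replacing 1-propylbutyl with 2,3-dihydroxypropyl gives an at least 4.2-fold lower number from compound 1 to compound 3 (0.62 log units; beyond the scatter), so the dihydroxy chain, like the 3-hydroxypropyl chain, stays beyond the scatter from the 1-propylbutyl group. The value of compound 1 is a limit, and the full size of that step stays unknown because of it: the limit of > 125000 nM in this assay, at which 1 of the 3 values shown sits.

From the compounds shown here alone, whether an amine or a carboxylic acid at the end of this chain, or a longer chain carrying hydroxy, would keep the number in the same region remains open.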